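The compounds below may be only part of what the source reports. "The series", "measured", "known", "first", "only" and "open" are said of these compounds alone.

Compound 1 `c1cc([C@H]2CC[C@]3(CC2)OOC2(O3)C3CC4CC(C3)CC2C4)ccc1OCCC1CCNCC1`: 1190 nM
Compound 2 `c1cc([C@H]2CC[C@]3(CC2)OOC2(O3)C3CC4CC(C3)CC2C4)ccc1OCC1CCNCC1`: 465 nM

Within the data shown here, in an ADME assay on the whole organism (strain FVB) for pharmacokinetics, with Mus musculus as the target, read by LC-MS, at a dose of 30 mg/kg by the oral route (a higher number here means more compound in the circulation at the dose given, a lower number less compound in the circulation), compound 2 gives 465 nM and so stands lowest of the two measured so far. Compound 3 `CC1(C)CC(O)(COc2ccc([C@H]3CC[C@]4(CC3)OOC3(O4)C4CC5CC(C4)CC3C5)cc2)CC(C)(C)N1` has not yet been measured. It differs from compound 2 as follows: 4-hydroxy-2,2,6,6-tetramethylpiperidin-4-yl in place of piperidin-4-yl on a saturated chain carbon bound to an oxygen on an aromatic ring on a saturated chain carbon bound to an oxygen on an aromatic ring. Among the measured compounds shown here, the only measured step, a 2.6-fold lower number from compound 1 to compound 2 (0.41 log units; beyond the scatter), swaps (piperidin-4-yl)methyl for piperidin-4-yl and adds no hydroxy or methyl group, so it is a weak guide that gives no clear direction. The expected change is therefore none beyond the scatter, with a 1.3-fold higher number from compound 2 to compound 3 (0.11 log units; within the scatter) as the estimated step. For compound 3 the estimate is 600 nM within a range of 170 nM to 2000 nM as expected.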

Compound 3, maximal plasma concentration: 1000 nM
Compound 3: middle estimate off by 1.7-fold (0.22 log units), on the low side; measured number inside the range.
By their numbers in this assay, from the lowest: compound 2; then compounds 3 and 1 (each within the scatter of the next).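

In this assay, the step at this position, on a saturated chain carbon bound to an oxygen on an aromatic ring, shows that the number does not fall when the hydroxy and methyl groups come in together: (a 2.2-fold higher number from compound 2 to compound 3 (0.33 log units; beyond the scatter)). Compared with the (piperidin-4-yl)methyl group, the new group gives a similar number (a 1.2-fold lower number from compound 1 to compound 3 (0.08 log units; within the scatter)). Nothing measured here explains these steps.

From the compounds shown here alone, compound 3 brings in the hydroxy and methyl groups at once, so the share of each stays open. Going by these compounds, how a carboxylic acid at this position would read is also open.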